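Removing the propoxy group from an inactive core

This account rests on a few compounds, and the source may have more. Where it says the series, first, only, none or still open, it means among the compounds named here.

Of the compounds shown here, two have been measured so far, and neither has yielded a number. Compound 1 `CCCOc1ccccc1-c1ncc2cnnc(O)n12` carries a propoxy group on a six-membered aromatic ring of carbon only. In a functional assay for inhibition, with Homo sapiens as the target (a lower number here means a stronger inhibitor, a higher number a weaker inhibitor), compound 1 returns only a limit of the assay, > 48000 nM. Compound 2 `CCCc1cnc(Nc2cc[nH]n2)n2c(C)ncc12`, built on a different core, is the second measured entry. In this assay compound 2 likewise returns only a limit, > 48000 nM. Compound 1 thus stands at the limit of > 48000 nM in this assay, at which 2 of the 2 values shown sit, and nothing measured separates the two. Among the measured compounds shown here, no step between measured compounds is available.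

Compound 3 `Oc1nncc2cnc(-c3ccccc3)n12` is the unmeasured compound. It differs from compound 1 by hydrogen in place of propoxy on an aromatic carbon. With compound 1 and compound 2 both at the limit, no direction for this change can be read from the measurements. The change is expected to bring a step that the limit leaves unreadable from compound 1 to compound 3, none beyond the scatter, and most likely to end again at a limit. Compound 3 is estimated at 60000 nM, within a range from 20000 nM to 200000 nM, with a limit being the most probable report.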

Compound 3, half-maximal inhibitory concentration: > 48000 nM
Compound 3: only a limit was reported (the forecaster's own chance of this, stated with the estimate: 85%); the middle value lies beyond the limit too.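

Compound 3, like compound 1, returns only a limit in this assay, so no step from hydrogen in place of propoxy can be read between them: the limit of > 48000 nM in this assay, at which 3 of the 3 values shown sit.

The compounds shown leave open whether any change to the core of compound 1 would give a measurable number in this assay.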